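The compounds below may be only part of what the source reports. "The series", "measured", "known", "first", "only" and "open" are said of these compounds alone.

Measured compounds:
- compound 1 `COc1cccc(C(=O)NNC(=O)c2ccc3[nH]c(-c4ccc([N+](=O)[O-])o4)nc3c2)c1`: 15.6 ug/mL
- compound 2 `O=CNNC(=O)c1ccc2[nH]c(-c3ccc([N+](=O)[O-])o3)nc2c1`: 62.5 ug/mL
- compound 3 `COc1ccc(C(=O)NNC(=O)c2ccc3[nH]c(-c4ccc([N+](=O)[O-])o4)nc3c2)cc1OC`: 31.3 ug/mL

In a functional assay on MCF7 cells (Homo sapiens) for inhibition, read by sulforhodamine B assay, with a stated time of 48 h (on this read-out higher numbers stand for weaker inhibition of growth and lower numbers for stronger inhibition of growth), compound 1 gives 15.6 ug/mL and shares the low end of this small set with compound 3. The two lie within the scatter of each other, with a 2.0-fold higher number from compound 1 to compound 3 (0.30 log units; within the scatter). Only compound 2 is set clearly apart from compound 1, with a 4.0-fold higher number from compound 1 to compound 2 (0.60 log units; beyond the scatter). Compound 2 and compound 3 are again within the scatter, with a 2.0-fold lower number from compound 2 to compound 3 (0.30 log units; within the scatter).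

Compound 4 `COc1cccc(C(=O)NNC(=O)c2ccc3[nH]c(-c4ccc([N+](=O)[O-])s4)nc3c2)c1` keeps everything in compound 1 except one group: 5-nitrothiophen-2-yl in place of 5-nitrofuran-2-yl on an aromatic carbon. Among the compounds with values here, none of the measured steps bears directly on this change, since all three compounds carry the 5-nitrofuran-2-yl group. Within the data shown here, what they offer is only a sense of how far the numbers have moved in this set, and the one step beyond the scatter, a 4.0-fold higher number from compound 1 to compound 2 (0.60 log units; beyond the scatter), is modest and removes a whole 3-methoxyphenyl group. From the compounds shown here alone, the data hold no comparison of 5-nitrothiophen-2-yl with 5-nitrofuran-2-yl, so the direction stays open.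

In this assay, no shift beyond the scatter is expected, and the estimate is no change at the digits printed from compound 1 to compound 4 (within the scatter). For compound 4 the expected value is 15.6 ug/mL. The estimated range for compound 4 runs from 5 ug/mL to 50 ug/mL.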

Compound 4, concentration for 50% growth inhibition: 15.6 ug/mL
Compound 4: the middle estimate sits on the measured number at the digits printed; measured number inside the range.
By their numbers in this assay, from the lowest: compounds 1, 4, 3 and 2 (each within the scatter of the next, the first and the last beyond it).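

In this assay, the only comparison shown at this position, on an aromatic carbon between two ring nitrogen atoms, places 5-nitrothiophen-2-yl in place of 5-nitrofuran-2-yl and gives no change at the digits printed from compound 1 to compound 4 (within the scatter). Compounds 1, 2 and 3 all carry 5-nitrofuran-2-yl and differ only elsewhere, whereas this pair holds the rest of the molecule fixed and shows that, with the 3-methoxyphenyl group present, sulfur can stand for oxygen in this five-membered aromatic ring with no shift in the growth read-out. No measurement is available that would explain this outcome.

From the compounds shown here alone, whether the same exchange would leave the number unchanged alongside the 3,4-dimethoxyphenyl group of compound 3 or the hydrogen of compound 2 remains open, as this single step was read only with the 3-methoxyphenyl group. Every compound shown also keeps a nitro group on its five-membered ring, leaving open how an amine in place of that nitro group, or a plain phenyl ring in place of the whole 5-nitrofuran-2-yl group, would read in this assay.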